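The source may report more compounds than this note shows. Statements on the series, on what has been measured and on what is new or still open speak of the compounds shown alone.

Measured in a physicochemical assay for permeability, using PAMPA; on this read-out higher numbers stand for higher permeability and lower numbers for lower permeability:
- Compound 1 `Cc1oc(-c2ccc(Cl)cc2)nc1CN1CCC(C(=O)NCCCN2C[C@H](C)C[C@H](C)C2)CC1`: > 635 10^-6 cm/s, a limit of the assay
- Compound 2 `Cc1oc(-c2c(F)cccc2F)nc1CN1CCC(C(=O)NCCCN2C[C@H](C)C[C@H](C)C2)CC1`: 82.4 10^-6 cm/s
- Compound 3 `Cc1ccc(-c2nc(CN3CCC(C(=O)NCCCN4C[C@H](C)C[C@H](C)C4)CC3)c(C)o2)cc1`: 274 10^-6 cm/s

Of the two true numbers, compound 3 holds the higher one, while the entry for compound 1 is only a limit. Compound 4 `Cc1cccc(C)c1-c1nc(CN2CCC(C(=O)NCCCN3C[C@H](C)C[C@H](C)C3)CC2)c(C)o1` differs from it by 2,6-dimethylphenyl in place of 4-methylphenyl on an aromatic carbon: 2,6-dimethylphenyl in place of 4-methylphenyl. The closest guide is compound 2, also substituted as a 2,6-disubstituted phenyl, with a 3.3-fold higher number from compound 2 to compound 3 (0.52 log units; beyond the scatter) and an at least 7.7-fold lower number from compound 1 to compound 2 (0.88 log units; beyond the scatter). The change of chloro to methyl gave an at least 2.3-fold lower number from compound 1 to compound 3 (0.36 log units; beyond the scatter). Since compound 2 carries fluoro rather than methyl, only part of that modest gap is expected to carry over, so a small fall in this assay is expected, possibly within the scatter. The expected step is a 1.4-fold lower number from compound 3 to compound 4 (0.16 log units; within the scatter). For compound 4 the estimated value is 190 10^-6 cm/s, with an expected range of 70 10^-6 cm/s to 520 10^-6 cm/s.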

Compound 4, apparent permeability: 254 10^-6 cm/s
Compound 4: middle estimate off by 1.3-fold (0.13 log units), on the low side; low and high end bracket the measured number.
By their numbers in this assay, from the lowest: compound 2; then compounds 4 and 3 (each within the scatter of the next). At a limit, above all of these: compound 1.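

In this assay, 2,6-dimethylphenyl and 4-methylphenyl could not be told apart on this aromatic carbon, with a 1.1-fold lower number from compound 3 to compound 4 (0.03 log units; within the scatter). A 2,6-disubstituted phenyl alone does not set the low number: exchanging 2,6-difluorophenyl for 2,6-dimethylphenyl gives a 3.1-fold higher number from compound 2 to compound 4 (0.49 log units; beyond the scatter). The comparison with 4-chlorophenyl reads an at least 2.5-fold lower number from compound 1 to compound 4 (0.39 log units; beyond the scatter), which is only a bound, for compound 1 stands at a limit: the limit of > 635 10^-6 cm/s in this assay, at which 1 of the 4 values shown sits.

On these data alone, it remains open where 2,6-dichlorophenyl would fall relative to the methyl and fluoro pairs. Also open, as far as these compounds go, is how a phenyl carrying an amine or a carboxylic acid would read in this assay.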